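Swapping Chloro for Methoxy in a Small Sulfonamide Series

The source may hold more compounds than are shown below. What is called first, only, known or untested is meant among the compounds shown, and "the series" means these compounds.

Measured in a functional assay on the whole organism with Mus musculus as the target; a lower number here means that less compound is needed, a higher number that more compound is needed for the effect:
- compound 1 `O=C(Cc1ccc(Cl)cc1)NS(=O)(=O)C(F)(F)F`: 49 mg/kg
- compound 2 `O=C(Cc1ccc([N+](=O)[O-])cc1)NS(=O)(=O)C(F)(F)F`: 20 mg/kg
- compound 3 `O=C(Cc1cccc(Cl)c1)NS(=O)(=O)C(F)(F)F`: 35 mg/kg

In this assay, compound 3 gives 35 mg/kg, which lies within the usual scatter of both compound 1 and compound 2. The next compound, compound 4 `COc1cccc(CC(=O)NS(=O)(=O)C(F)(F)F)c1`, carries methoxy in place of chloro on an aromatic carbon, and the change from compound 3 is methoxy in place of chloro on an aromatic carbon. Within the data shown here, no measured compound carries methoxy, so there is no direct precedent. Among the measured compounds shown here, the only measured step that replaces chloro is a 2.5-fold lower number from compound 1 to compound 2 (0.39 log units; beyond the scatter), a modest change, and it brings in nitro rather than methoxy. That step shows that a replacement of chloro can move the number, but it gives no direction for methoxy. A clear shift is therefore not expected, and an estimated 1.1-fold higher number from compound 3 to compound 4 (0.04 log units; within the scatter) would stay within the scatter. For compound 4 the expected value is 38 mg/kg, with an estimated range of 17 mg/kg to 85 mg/kg.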

Compound 4, dose for half-maximal effect: 77 mg/kg
Compound 4: middle estimate off by 2.0-fold (0.31 log units), on the low side; measured number inside the range.
By their numbers in this assay, from the lowest: compounds 2, 3, 1 and 4 (each within the scatter of the next, the first and the last beyond it).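

Methoxy in place of chloro, on an aromatic carbon meta to a large group, gives a 2.2-fold higher number from compound 3 to compound 4 (0.34 log units; beyond the scatter) in this assay. This shows that the number at this position depends on the group it carries, and that replacing chloro can raise the number as well as lower it: the only earlier replacement, a 2.5-fold lower number from compound 1 to compound 2 (0.39 log units; beyond the scatter), brought nitro at a different position and went the other way. Nothing available explains the rise.

Going by these compounds, whether a hydroxy group, an amine or a longer chain such as ethoxy at this position would move the number further, and in which direction, remains open. On these data alone, it is also open whether methoxy at the position substituted in compound 1 and compound 2 would give a step of similar size.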